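A dimethylphenyl swap in a series stuck at a limit

A few compounds are considered here, and "the series" means these few. Any claim that something is new, unique, unknown or untested is made for them only; others in the source may bear on it.

In a functional assay on HFF cells (Homo sapiens) for cytotoxicity (a higher number here means a weaker inhibitor, a lower number a stronger inhibitor), compound 3 `O=C1/C(=C/c2ccc(Cl)c(Cl)c2)SC(=S)N1NS(=O)(=O)c1ccccc1` gives > 100000 nM, which is a limit and not a number. Compound 1 `COc1cccc(/C=C2\SC(=S)N(NS(=O)(=O)c3ccccc3)C2=O)c1` gives > 100000 nM, also a limit. Compound 2 `O=C1/C(=C/c2ccc([N+](=O)[O-])cc2)SC(=S)N1NS(=O)(=O)c1ccccc1` gives > 100000 nM, again a limit. Compound 3 therefore has no numerical rank among its neighbours, and the whole picture so far is the limit of > 100000 nM in this assay, at which 3 of the 3 values shown sit.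

Compound 4 `Cc1ccc(/C=C2\SC(=S)N(NS(=O)(=O)c3ccccc3)C2=O)cc1C` carries 3,4-dimethylphenyl in place of 3,4-dichlorophenyl on a double-bonded chain carbon bound to a double-bonded ring carbon.

The measured changes at this same place are a step that the two limits leave unreadable from compound 1 to compound 3, a step that the two limits leave unreadable from compound 2 to compound 3 and a step that the two limits leave unreadable from compound 1 to compound 2. None of these has a readable size, so they point in no direction, but all three groups tried there ended at the limit in this assay. No step beyond the usual scatter is therefore expected. The expected outcome is a number no higher from compound 3 to compound 4 (the limit leaves the size open), with neither direction favoured. The estimate for compound 4 is 100000 nM, expected to fall in the range 50000 nM to 200000 nM, and most likely to be reported only as a limit again.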

Compound 4, half-maximal inhibitory concentration: > 100000 nM
Compound 4: a limit, no number; the forecaster's own chance of this, stated with the estimate: 85%; the middle value lies on the limit itself.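

In this assay compound 4 gives > 100000 nM, which is a limit and not a number. Its steps from compound 1, compound 2 and compound 3 therefore cannot be read. The compounds shown leave open how these four aryl groups rank against one another: the limit of > 100000 nM in this assay, at which 4 of the 4 values shown sit.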